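The source may hold more compounds than are shown below. What is called first, only, known or untested is meant among the compounds shown, and "the series" means these compounds.

Measured so far:
compound 1, `CSCC[C@@H](N)C(=O)NCc1ccccc1` — > 76 mg/kg
compound 2, `CCC[C@H](N)C(=O)NCc1ccccc1` — 100 mg/kg

Going by the values given here, in a functional assay on the whole organism (strain NMRI) for inhibition, with Mus musculus as the target, in the formalin test, with a stated time of 30 min (a lower number here means that less compound is needed, a higher number that more compound is needed for the effect), compound 2 gives 100 mg/kg, the only number in the set. For compound 1 the result is a limit of the assay, > 76 mg/kg. That result is the limit of > 76 mg/kg in this assay, at which 1 of the 2 values shown sits. Compound 3, `CCC[C@@H](N)C(=O)NCc1ccccc1`, is not yet measured. (the two compounds have the same atoms and bonds and differ only in configuration as drawn: 1 of 1 stereo elements differ; a stereocentre at a saturated chain carbon is drawn S in compound 2 and R in compound 3). Among the compounds with values here, no pair of measured compounds differing in one place is available, so the change in configuration carries no measured precedent here. The step from compound 2 is expected to stay within the scatter, with no direction favoured. Compound 3 is estimated at 80 mg/kg, with a range of 25 mg/kg to 250 mg/kg. The expected step is a 1.3-fold lower number from compound 2 to compound 3 (0.10 log units; within the scatter).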

Compound 3, dose for half-maximal effect: 35 mg/kg
Estimate against measurement, compound 3: 2.3-fold (0.36 log units) above; measured number inside the range.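

In this assay, configuration at this saturated chain carbon counts, with R ahead of S by a 2.9-fold lower number from compound 2 to compound 3 (0.46 log units; beyond the scatter), and no other structural change is involved: the fact that compounds 2 and 3 differ only in the configuration as drawn

Compound 1 gives only a limit of the assay, > 76 mg/kg. Methyl in place of methylsulfanyl on the chain still gives an at least 2.1-fold lower number from compound 1 to compound 3 (0.33 log units; beyond the scatter), so the R compound with the methyl ending is the best placed of the compounds shown.

Open, going by these compounds, is whether a longer chain or a phenyl group at this stereocentre keeps the same preference for R. Whether a hydroxyl group in place of the methyl ending is tolerated also remains open.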